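The source may report more compounds than this note shows. Statements on the series, on what has been measured and on what is new or still open speak of the compounds shown alone.

Measured so far in a functional assay on M21 cells (Homo sapiens) for antiproliferative activity, read by sulforhodamine B assay, with a stated time of 48 h; on this read-out higher numbers stand for weaker inhibition and lower numbers for stronger inhibition:
- compound 1 `Cc1ccc(NS(=O)(=O)c2ccc(N3CCNC3=O)cc2)cc1C`: 94 nM
- compound 2 `Cc1ccc(C)c(NS(=O)(=O)c2ccc(N3CCNC3=O)cc2)c1`: 27 nM

Compound 2 has the lower of these two numbers, so it stands as the stronger inhibitor of the pair. For the measured compounds named here, the only measured step is a 3.5-fold lower number from compound 1 to compound 2 (0.54 log units; beyond the scatter). It is modest but larger than the usual scatter, and it shows that changing only the group on the sulfonamide nitrogen can move the number.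

Compound 3 `COc1ccccc1NS(=O)(=O)c1ccc(N2CCNC2=O)cc1` has not yet been measured. It carries 2-methoxyphenyl in place of 2,5-dimethylphenyl on a sulfonamide nitrogen. Going by the values given here, no measured compound carries 2-methoxyphenyl, so the one step available is only a rough guide.

Going by the size of a 3.5-fold lower number from compound 1 to compound 2 (0.54 log units; beyond the scatter), a step of similar modest size is expected in this assay. Its direction is expected to be towards a higher number, as compound 2 at 27 nM sits at the low end of the two values. The expected step is a 3.3-fold higher number from compound 2 to compound 3 (0.52 log units; beyond the scatter). For compound 3 the estimate is 90 nM, with an expected range of 25 nM to 320 nM.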

Compound 3, half-maximal inhibitory concentration: 300 nM
Compound 3: the middle estimate sits 3.3-fold (0.52 log units) below what was measured; the range from low to high includes it.
By their numbers in this assay, from the lowest: compound 2; then compound 1; then compound 3.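

In this assay, putting 2-methoxyphenyl on the sulfonamide nitrogen gives an 11-fold higher number from compound 2 to compound 3 (1.05 log units; beyond the scatter), a large step that shows this position can move the number much further than the first comparison suggested. The same change measured against the other dimethylphenyl compound gives a 3.2-fold higher number from compound 1 to compound 3 (0.50 log units; beyond the scatter), so compound 3 is the weakest inhibitor of the three, and its number is higher than those of both dimethylphenyl compounds, not just the better one. The two groups exchanged in the large step both hold 8 heavy atoms and one six-membered aromatic ring, so a matching heavy-atom count and ring did not keep the number in place; the entering group has an oxygen and 1 hydrogen-bond acceptor, and the leaving group has neither.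

Nothing available explains why the number rises with this change. The compounds shown do not tell apart the removal of the 5-methyl group and the addition of the methoxy group within this step. 2-methylphenyl and 2-methoxy-5-methylphenyl on the same nitrogen would help to separate the two.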